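This account rests on a few compounds, and the source may have more. Where it says the series, first, only, none or still open, it means among the compounds named here.

Compound 1 `CN1CCN(c2ccc(N/C=C3\C(=O)NC(=O)c4ccc(-n5cccc5)cc43)cc2)CC1`: 1500 nM
Compound 2 `O=C1NC(=O)c2ccc(I)cc2/C1=C/Nc1ccc(CN2CCCCC2)cc1`: 2700 nM

In a functional assay on HCT-116 cells (Homo sapiens) for antiproliferative activity, read by sulforhodamine B assay (on this read-out lower numbers stand for stronger inhibition and higher numbers for weaker inhibition), compound 1 gives 1500 nM and compound 2 gives 2700 nM. Among the measured compounds shown here, these two values lie within the usual scatter of each other, so compound 1 sits level with the only other number available. For the measured compounds named here, no measured pair isolates a change at the position of interest.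

Compound 3 `CN1CCN(c2ccc(N/C=C3\C(=O)NC(=O)c4ccc(-c5ccsc5)cc43)cc2)CC1` has thiophen-3-yl in place of 1H-pyrrol-1-yl on an aromatic carbon of the shared core: thiophen-3-yl in place of 1H-pyrrol-1-yl on an aromatic carbon. Each group is one five-membered aromatic ring with 1 hetero atom.

Going by the values given here, with no measured step to draw on, the expectation rests on compound 1 at 1500 nM. No step beyond the scatter is expected in this assay, and no firm direction is expected either. The estimated change is a 1.2-fold lower number from compound 1 to compound 3 (0.06 log units; within the scatter). For compound 3 the expected value is 1300 nM, with an estimated range from 450 nM to 3800 nM.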

Compound 3, half-maximal inhibitory concentration: 1400 nM
For compound 3 the middle estimate is 1.1-fold (0.03 log units) below the measured one, within the range that was stated.
By their numbers in this assay, from the lowest: compounds 3, 1 and 2 (each within the scatter of the next).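

In this assay a matched step at this position can now be read: thiophen-3-yl in place of 1H-pyrrol-1-yl on an aromatic carbon gives a 1.1-fold lower number from compound 1 to compound 3 (0.03 log units; within the scatter) and so does not separate the two groups. At this position, one five-membered aromatic ring with 1 hetero atom can therefore stand in for another, with sulfur replacing nitrogen, without a step beyond the scatter. No supporting data are available to explain this result.

From the compounds shown here alone, whether the position accepts groups of a different kind, such as a carboxylic acid, a dimethylamino group or a longer alkyl chain, remains open. Going by these compounds, compound 2 differs from compound 1 in more than one place, so the separate contribution of each of its differences also remains open.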